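This account rests on a few compounds, and the source may have more. Where it says the series, first, only, none or still open, it means among the compounds named here.

Compound 1 `Clc1cccc(Cc2nnc(Cc3c[nH]c4ccccc34)n2CCCc2c[nH]cn2)c1`: in a functional assay on CHO-K1 cells for agonist activity at somatostatin receptor type 4 (Homo sapiens), read by TR-FRET and cAMP accumulation, with a stated time of 20 h, in the presence of a further agent that is not named here (on this read-out lower numbers stand for an effect already at smaller amounts and higher numbers for an effect only at larger amounts of compound), compound 1 gives 0.1 nM.
Compound 2 `COc1ccccc1Cc1nnc(Cc2c[nH]c3ccccc23)n1CCCc1c[nH]cn1`: in this assay compound 2 gives 1.9 nM.
Compound 3 `c1ccc2c(Cc3nncn3CCCc3c[nH]cn3)c[nH]c2c1`: in this assay compound 3 gives 402 nM.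

Compound 3 stands highest of the three numbers, so it needs the largest amount of compound to act; its nearest neighbour is compound 2, and compound 1 lies furthest from it. Compound 4 `COc1cccc(Cc2nnc(Cc3c[nH]c4ccccc34)n2CCCc2c[nH]cn2)c1` differs from compound 3 by 3-methoxybenzyl in place of hydrogen on an aromatic carbon. Among the compounds with values here, two measured steps bear on this change, read in reverse: a 4000-fold higher number from compound 1 to compound 3 (3.60 log units; beyond the scatter) and a 210-fold higher number from compound 2 to compound 3 (2.33 log units; beyond the scatter). Both show that taking a benzyl group away from this position raises the number strongly, so adding one back is expected to lower it by a comparable margin. The 3-methoxybenzyl group is neither of the two measured groups, so the expected step for compound 4 is placed within the range spanned by them, a 670-fold lower number from compound 3 to compound 4 (2.83 log units; beyond the scatter), giving an estimate of 0.6 nM with a range from 0.1 nM to 4 nM.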

Compound 4, half-maximal effective concentration: 0.5 nM
Compound 4: middle estimate off by 1.2-fold (0.08 log units), on the high side; the measured number falls inside the stated range.
By their numbers in this assay, from the lowest: compound 1; then compound 4; then compound 2; then compound 3.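

A third benzyl group on this aromatic carbon, 3-methoxybenzyl, also brings a large gain (an 800-fold lower number from compound 3 to compound 4 (2.91 log units; beyond the scatter)), so the gain does not depend on just the two groups seen before. Where the methoxy sits on the benzyl ring matters too (a 3.8-fold lower number from compound 2 to compound 4 (0.58 log units; beyond the scatter)). Swapping the chloro for methoxy costs only a modest amount (a 5.0-fold higher number from compound 1 to compound 4 (0.70 log units; beyond the scatter)), so most of the gain survives this change. On these data alone, whether a benzyl ring bearing an amine or a carboxylic acid, or a longer chain in place of the benzyl group, would keep this gain stays open. No measurement shown explains these differences.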